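A few compounds are considered here, and "the series" means these few. Any claim that something is new, unique, unknown or untested is made for them only; others in the source may bear on it.

Compound 2, `N#Cc1ccc(Nc2nccc(Oc3ccc(-c4ccc(C#N)cc4)cc3F)n2)cc1`, is known here only up to a bound: in a functional assay on MT4 cells (Homo sapiens) for cytotoxicity, read by MTT assay, with a stated time of 5 days (a lower number here means that less compound is tolerated, a higher number that more compound is tolerated), compound 2 gives > 307000 nM, which is a limit of the assay rather than a number. Compound 1, `Cc1cc(-c2ccc(Oc3ccnc(Nc4ccc(C#N)cc4)n3)c(F)c2)ccc1C#N`, in this assay gives > 296000 nM, likewise a limit. The step that the two limits leave unreadable from compound 1 to compound 2 therefore cannot be sized. Compound 3 is `N#Cc1ccc(Nc2nccc(Oc3ccc(-c4ccc(C#N)cc4F)cc3F)n2)cc1`; its difference from compound 2 is fluoro in place of hydrogen on an aromatic carbon. Since no measured step can be read, compound 3 is expected to remain at the limit, and an at least 1.0-fold lower number from compound 2 to compound 3 (0.01 log units; that floor lies within the scatter) is expected to be no step beyond the scatter. Compound 3 is estimated at 300000 nM, between 150000 nM and 600000 nM.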

Compound 3, half-maximal cytotoxic concentration: > 294000 nM
Compound 3 gave a limit, no number; the forecaster's own chance of this, stated with the estimate: 80%; the middle value is on the limit's open side.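

Among the compounds shown here, compound 1, compound 2 and compound 3 each give only a limit, and no step among them can be read. The compounds shown leave open at what concentration each becomes toxic to the cells, and whether the fluoro or methyl groups change that.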